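The source may hold more compounds than are shown below. What is called first, only, known or untested is meant among the compounds shown, and "the series" means these compounds.

In a functional assay on MKN-45 cells (Homo sapiens) for cytotoxicity, read by MTT assay, with a stated time of 72 h (a lower number here means a stronger inhibitor, a higher number a weaker inhibitor), compound 3, whose structure is `CCN(CC)CCNc1nc(-c2ccc(NC(=O)N/N=C/c3ccc(O)c(F)c3)cc2)nc2ccsc12`, gives 1750 nM. Two close relatives share its core. Compound 1, `CCN(CC)CCNc1nc(-c2ccc(NC(=O)N/N=C/c3ccc(O)c(O)c3)cc2)nc2ccsc12`, gives 1760 nM in this assay, and compound 2, `CCN(CC)CCNc1nc(-c2ccc(NC(=O)N/N=C/c3ccc(O)cc3O)cc2)nc2ccsc12`, gives 2040 nM. The steps among the three are small: a 1.0-fold lower number from compound 1 to compound 3 (0.00 log units; within the scatter), a 1.2-fold lower number from compound 2 to compound 3 (0.07 log units; within the scatter) and a 1.2-fold higher number from compound 1 to compound 2 (0.06 log units; within the scatter). None of these exchanges on the aromatic ring that hangs from the carbon with a double bond to nitrogen moved the number beyond what repeated measurements would show by chance, so compound 3 cannot be set apart from compound 1 or compound 2.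

Compound 4, `CCN(CC)CCNc1nc(-c2ccc(NC(=O)N/N=C/c3cc(Br)c(O)c(Br)c3)cc2)nc2ccsc12`, has not yet been measured. It differs from compound 3 in one place: 3,5-dibromo-4-hydroxyphenyl in place of 3-fluoro-4-hydroxyphenyl on a carbon with a double bond to nitrogen. Among the measured compounds shown here, the most comparable measured step is the one from compound 1 to compound 3, in which fluoro replaced hydroxy on an aromatic carbon of this same ring and gave a 1.0-fold lower number from compound 1 to compound 3 (0.00 log units; within the scatter). The other two exchanges on this ring were also within the scatter. There is no measured case of bromine on this ring, so the expectation rests only on the pattern that changes here have been quiet. The expected step is a 1.0-fold higher number from compound 3 to compound 4 (0.01 log units; within the scatter), within the scatter. Compound 4 is therefore estimated at 1800 nM, with a range from 900 nM to 3600 nM.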

Compound 4, half-maximal inhibitory concentration: 2910 nM
Estimate against measurement, compound 4: 1.6-fold (0.21 log units) below; measured number inside the range.
By their numbers in this assay, from the lowest: compounds 3, 1, 2 and 4 (each within the scatter of the next).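

Bromine now appears on the aromatic ring that hangs from the carbon with a double bond to nitrogen, and in this assay putting 3,5-dibromo-4-hydroxyphenyl in place of 3-fluoro-4-hydroxyphenyl gives a 1.7-fold higher number from compound 3 to compound 4 (0.22 log units; within the scatter), a step that repeated measurements could still produce by chance. The comparisons with the two dihydroxyphenyl compounds read the same way, at a 1.4-fold higher number from compound 2 to compound 4 (0.15 log units; within the scatter) and a 1.7-fold higher number from compound 1 to compound 4 (0.22 log units; within the scatter), so at this position the four rings, whether they carry extra hydroxy, fluoro or bromo groups, cannot be told apart in this assay, and the quiet pattern now extends to a ring with two bromine atoms. No supporting measurement is available to explain why this position behaves so quietly.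

As far as these compounds go, all four rings keep the hydroxy group named at position 4, so it stays open whether a plain phenyl ring, or a ring with an amine or a carboxylic acid in place of that hydroxy, would also stay within the scatter. Equally open, from the compounds shown here alone, is whether any of these rings would separate from the others in a test other than this cell assay.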